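Aryl swaps on the triazole nitrogen: outlook for compound 4

The source may report more compounds than this note shows. Statements on the series, on what has been measured and on what is new or still open speak of the compounds shown alone.

Measured in a functional assay on A549 cells (Homo sapiens) for inhibition, read by MTT assay, with a stated time of 24 h; on this read-out higher numbers stand for weaker inhibition and lower numbers for stronger inhibition:
Compound 1 `CC1(C)[C@H]2CC[C@]1(C)N(Cc1cn(-c3ccccc3Cl)nn1)C(=O)C2` gives 70 nM.
Compound 2 `CC1(C)[C@H]2CC[C@]1(C)N(Cc1cn(-c3ccc(O)cc3)nn1)C(=O)C2` gives 140 nM.
Compound 3 `COc1ccc(-n2cc(CN3C(=O)C[C@@H]4CC[C@@]3(C)C4(C)C)nn2)cc1` gives 50 nM.

Compound 2 holds the highest number of the three. The step of a 2.0-fold higher number from compound 1 to compound 2 (0.30 log units; within the scatter) leaves compound 1 and compound 2 indistinguishable, whereas a 2.8-fold lower number from compound 2 to compound 3 (0.45 log units; beyond the scatter) separates compound 2 from compound 3.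

Compound 4 `Cc1cccc(-n2cc(CN3C(=O)C[C@@H]4CC[C@@]3(C)C4(C)C)nn2)c1` is the next step from compound 2: 3-methylphenyl in place of 4-hydroxyphenyl on an aromatic nitrogen

Within the data shown here, two measured steps bear on it. Capping the hydroxyl, a 2.8-fold lower number from compound 2 to compound 3 (0.45 log units; beyond the scatter), lowered the number modestly; replacing the 2-chlorophenyl with the 4-hydroxyphenyl, a 2.0-fold higher number from compound 1 to compound 2 (0.30 log units; within the scatter), stayed within the scatter. Among the measured compounds shown here, no step to a 3-methylphenyl exists. For compound 4 a modest step down toward the numbers of compound 1 and compound 3 is expected, a 2.2-fold lower number from compound 2 to compound 4 (0.33 log units; beyond the scatter). Compound 4 is estimated at 65 nM, range 30 nM to 150 nM.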

Compound 4, half-maximal inhibitory concentration: 50 nM
The estimate for compound 4 lay 1.3-fold (0.11 log units) above the measured number; the range from low to high includes it.
By their numbers in this assay, from the lowest: compounds 3, 4, 1 and 2 (each within the scatter of the next, the first and the last beyond it).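

Dropping the hydroxyl without keeping an oxygen on the aryl ring still gives a 2.8-fold lower number from compound 2 to compound 4 (0.45 log units; beyond the scatter), so on this aromatic nitrogen the 3-methylphenyl, with 0 hydrogen-bond donors and 0 acceptors, matches the step seen with the 4-methoxyphenyl. The other aryl swaps stay unresolved, with no change at the digits printed from compound 3 to compound 4 (within the scatter) and a 1.4-fold lower number from compound 1 to compound 4 (0.15 log units; within the scatter), and compound 1 goes against any clean split, lying within the scatter of compound 2 as well. No measurement at hand accounts for these steps.

Open, as far as these compounds go, is whether an amine or a carboxylic acid on the phenyl ring, or a longer chain in place of the methyl, would move the number outside this narrow band.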